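A Chloro Group on a Rapidly Cleared Compound

The source may hold more compounds than are shown below. What is called first, only, known or untested is meant among the compounds shown, and "the series" means these compounds.

In an ADME assay (liver) for metabolic stability, with Liver microsome (Homo sapiens) as the target, read by LC-MS, using microsomes and NADPH, with a stated time of 5 min, at 37 degrees C (on this read-out lower numbers stand for slow clearance and higher numbers for fast clearance), compound 1 (`CCn1c([C@@H](C)NS(=O)(=O)c2ccc(Cl)cc2)nc2ccccc21`) gives > 100 mL.min-1.g-1, which is a limit and not a number. Compound 2 (`CCn1c([C@@H](C)NS(=O)(=O)c2ccc(Cl)cc2)nc2cc(C#N)ccc21`) gives 71 mL.min-1.g-1. Compound 3 (`CCn1c([C@@H](C)NS(=O)(=O)c2ccc(Cl)cc2)nc2ccc(S(C)(=O)=O)cc21`) gives < 5 mL.min-1.g-1, also a limit. Cyano in place of hydrogen on an aromatic carbon gives an at least 1.4-fold lower number from compound 1 to compound 2 (0.14 log units; that floor lies within the scatter). Methylsulfonyl in the same kind of swap gives an at least 20-fold lower number from compound 1 to compound 3 (1.30 log units; beyond the scatter). Compound 4 (`CCn1c([C@@H](C)NS(=O)(=O)c2ccc(Cl)cc2)nc2cccc(Cl)c21`) differs from compound 1 by chloro in place of hydrogen on an aromatic carbon. Neither measured step adds chloro, so they guide direction better than size. A modest lowering, nearer the cyano step, is expected: an at least 1.6-fold lower number from compound 1 to compound 4 (0.22 log units; that floor lies within the scatter). Compound 4 is estimated at 60 mL.min-1.g-1, within an expected range of 20 mL.min-1.g-1 to 130 mL.min-1.g-1.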

Compound 4, intrinsic clearance in microsomes: > 100 mL.min-1.g-1
Compound 4: only a limit was reported (the forecaster's own chance of this, stated with the estimate: 25%); middle value at least 1.6-fold (0.22 log units) from the limit.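

Compound 1 and compound 4 both stand at the same limit of the read-out rather than at a number, so the step between them cannot be read. The compounds shown leave open whether chloro in place of hydrogen changes clearance at all, and by how much.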